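From a ((4-Fluorophenyl)carbamoyl)amino Group Back to a Simple Aryl Urea

This account rests on a few compounds, and the source may have more. Where it says the series, first, only, none or still open, it means among the compounds named here.

Measured in a functional assay on CCRF-CEM cells (Homo sapiens) for inhibition, read by MTT assay, with a stated time of 72 h; on this read-out higher numbers stand for weaker inhibition and lower numbers for stronger inhibition:
Compound 1, `COc1cc(NC(C)CCCNC(=O)Nc2cccc(Cl)c2)c2ncccc2c1`: 22000 nM
Compound 2, `COc1cc(NC(C)CCCNC(=O)Nc2ccc(Br)cc2)c2ncccc2c1`: 23000 nM
Compound 3, `COc1cc(NC(C)CCCNC(=O)NNC(=O)Nc2ccc(F)cc2)c2ncccc2c1`: 118000 nM

The three compounds share one core and differ only in the group carried on the amide-type nitrogen of the urea. Compound 3 stands highest of the three numbers in this assay: its nearest neighbour is compound 2, with the step of a 5.1-fold higher number from compound 2 to compound 3 (0.71 log units; beyond the scatter), and its furthest is compound 1, with the step of a 5.4-fold higher number from compound 1 to compound 3 (0.73 log units; beyond the scatter). Compounds 1 and 2 themselves lie within the scatter of each other, as the step of a 1.0-fold higher number from compound 1 to compound 2 (0.02 log units; within the scatter) shows.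

Compound 4, `COc1cc(NC(C)CCCNC(=O)Nc2ccc(F)cc2)c2ncccc2c1`, has not yet been measured. 4-fluorophenyl in place of ((4-fluorophenyl)carbamoyl)amino on an amide-type nitrogen This change undoes, in the reverse direction, the kind of extension seen in the steps from compound 1 and compound 2 to compound 3, which both raised the number by a modest amount beyond the scatter. The same two steps therefore bear on the expectation for compound 4: a modest step downward in this assay, toward the numbers of compounds 1 and 2, is expected, as the estimated step of a 4.9-fold lower number from compound 3 to compound 4 (0.69 log units; beyond the scatter) expresses. Compound 4 is accordingly estimated at 24000 nM, within a range from 12000 nM to 50000 nM.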

Compound 4, half-maximal inhibitory concentration: 26000 nM
Compound 4: the middle estimate sits 1.1-fold (0.03 log units) below what was measured, within the range that was stated.
By their numbers in this assay, from the lowest: compounds 1, 2 and 4 (each within the scatter of the next); then compound 3.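

In this assay, within the data shown here, 4-fluorophenyl in place of ((4-fluorophenyl)carbamoyl)amino on the amide-type nitrogen gives a 4.5-fold lower number from compound 3 to compound 4 (0.66 log units; beyond the scatter), which compares the same fluorinated ring with and without the extension, something the earlier compounds, with their different aryl groups, could not do. The new compound also adds a third aryl urea that does not separate from the other two: fluoro in place of bromo gives a 1.1-fold higher number from compound 2 to compound 4 (0.05 log units; within the scatter), and 4-fluorophenyl in place of 3-chlorophenyl gives a 1.2-fold higher number from compound 1 to compound 4 (0.07 log units; within the scatter), so across these three aryl groups the number does not move beyond the scatter. No measurement shown here offers an explanation for either finding.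

From the compounds shown here alone, it remains open whether an unsubstituted phenyl, or a phenyl carrying an amine or a carboxylic acid, would stay at this level. Whether a longer chain in the linker would shift the number is also unanswered.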